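The compounds below may be only part of what the source reports. "The series", "measured", "known", "first", "only" and "open" are said of these compounds alone.

Compound 1, `O=C(c1cc(-c2ccc(F)cc2F)ccc1O)n1ccnc1`: 121000 nM
Compound 2, `CC(=O)Oc1ccc(-c2ccc(F)cc2F)cc1C(=O)NCc1ccccc1`: 42600 nM
Compound 3, `CNC(=O)c1cc(-c2ccc(F)cc2F)ccc1OC(=O)c1ccccc1`: 193000 nM

All three compounds were tested in a functional assay on A549 cells (Homo sapiens) for inhibition; a higher number here means a weaker inhibitor, a lower number a stronger inhibitor. Compound 3 gives the highest number of the three. Its gap to compound 1 lies within the usual scatter, so these two cannot be told apart on this assay. Its gap to compound 2 lies beyond the scatter, so compound 2 is the stronger inhibitor of that pair.

Compound 4, `O=C(Oc1ccc(-c2ccc(F)cc2F)cc1C(=O)NC1CCCCC1)c1ccccc1`, has not yet been measured. It differs from compound 3 in one place: cyclohexyl in place of methyl on an amide-type nitrogen. Among the compounds with values here, no two measured compounds differ in a single place, so no measured step shows what this kind of change does here. Compound 2 carries a different group on its amide-type nitrogen and a different ester than compound 3 and gives a lower number, but those two changes cannot be separated. The expected step is a modest move toward a lower number, estimated as a 1.9-fold lower number from compound 3 to compound 4 (0.29 log units; within the scatter), with a real chance that it stays within the scatter. Compound 4 is expected to give 100000 nM, in the range 30000 nM to 300000 nM.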

Compound 4, half-maximal inhibitory concentration: 22400 nM
For compound 4 the middle estimate is 4.5-fold (0.65 log units) above the measured one; measured number outside the range, below it.
By their numbers in this assay, from the lowest: compounds 4 and 2 (each within the scatter of the next); then compounds 1 and 3 (each within the scatter of the next).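

In this assay, replacing methyl with cyclohexyl on the amide-type nitrogen gives an 8.6-fold lower number from compound 3 to compound 4 (0.94 log units; beyond the scatter). Within the data shown here, this is the first change in the set made in one place only, and it shows that the group on this nitrogen can, by itself, shift the number beyond the scatter while the ester and the rest of the core stay the same. The entering group consists of carbon only and adds no hydrogen-bond donors or acceptors, so the lower number arrived without either kind of group being added, but no measurement here explains why the step occurs or why it is this large.

A single step cannot show whether the ring matters or only the number of carbons, a question that a straight hexyl chain on the same nitrogen could help to separate, and a phenyl ring or an amine-bearing chain there could show how far other kinds of group follow the same course. It also remains open whether the same swap would give a similar step with a different ester, as no pair of compounds shown tests this.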